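One Number and a Changed Chain

The compounds below may be only part of what the source reports. "The series", "measured", "known", "first", "only" and "open" are said of these compounds alone.

Results so far in a functional assay on ES2 cells (Homo sapiens) for inhibition, read by MTT assay, with a stated time of 48 h; on this read-out higher numbers stand for weaker inhibition and lower numbers for stronger inhibition:
Compound 1 `O=S(=O)(c1ccccc1)c1c(OCCCCCCO)no[n+]1[O-]` gives "not determined" (no result reported) (no result reported)
Compound 2 `CC(C)(COc1no[n+]([O-])c1S(=O)(=O)c1ccccc1)C(=O)NO` gives 6880 nM

Only compound 2 has a number, so it cannot yet be ranked against anything. Its value is the sole reference point in this assay for now. The next compound to be tested is compound 3 `O=C(/C=C/COc1no[n+]([O-])c1S(=O)(=O)c1ccccc1)NO`, which keeps the shared core and alters only the chain. The change is 2-(hydroxycarbamoyl)ethenyl in place of 1-(hydroxycarbamoyl)-1-methylethyl on a saturated chain carbon bound to an oxygen on an aromatic ring and in words it places 2-(hydroxycarbamoyl)ethenyl in place of 1-(hydroxycarbamoyl)-1-methylethyl on a saturated chain carbon bound to an oxygen on an aromatic ring. Both groups carry a hydroxycarbamoyl ending. Going by the values given here, no measured step exists to show what such a change does, and compound 2 at 6880 nM is the only anchor for a prediction. No change beyond the usual scatter is therefore expected, with only a slight lean toward stronger inhibition. The expected change is a 1.4-fold lower number from compound 2 to compound 3 (0.14 log units; within the scatter) and it would stay within that scatter. Compound 3 is estimated at 5000 nM with an expected range from 1200 nM to 20000 nM once it is measured.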

Compound 3, half-maximal inhibitory concentration: 19100 nM
Beside the measured number, compound 3's estimate is 3.8-fold (0.58 log units) below it; the range from low to high includes it.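

In this assay, going by these compounds alone, putting 2-(hydroxycarbamoyl)ethenyl in place of 1-(hydroxycarbamoyl)-1-methylethyl gives a 2.8-fold higher number from compound 2 to compound 3 (0.44 log units; beyond the scatter), a modest weakening of inhibition and the first sign that the group on this saturated chain carbon bound to an oxygen on an aromatic ring affects the read-out. Both groups carry the hydroxycarbamoyl ending, so keeping that ending does not by itself hold the number steady; the difference lies in the rest of the group, where a branched saturated stretch gives way to an ethenyl link. Nothing available here explains why the number rises with this change.

Within the data shown here, compound 1 has no number, so no step to it can be read, and whether the hydroxycarbamoyl ending is needed at all stays open. Also open, as far as these compounds go, is which part of the change matters, the new double bond or the lost branching, and how the number would respond to a straight saturated chain with the same ending, a longer chain, or a carboxylic acid in place of the hydroxycarbamoyl group.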